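Shifting the amide aryl substituent to meta-methyl

The source may hold more compounds than are shown below. What is called first, only, known or untested is meant among the compounds shown, and "the series" means these compounds.

This series shares one core, seen in compound 1 `O=C(Nc1cccc(Cl)c1)c1ccc(/N=N\c2c[nH]c3ccccc23)cc1`, compound 2 `Cc1ccccc1NC(=O)c1ccc(/N=N\c2c[nH]c3ccccc23)cc1` and compound 3 `O=C(Nc1ccc(Cl)cc1)c1ccc(/N=N\c2c[nH]c3ccccc23)cc1`, and the three differ only in the aryl group on the amide nitrogen. In a functional assay on HCT-116 cells (Homo sapiens) for inhibition, read by MTT assay, with a stated time of 72 h (a lower number here means a stronger inhibitor, a higher number a weaker inhibitor), compound 1 gives 80000 nM, compound 2 gives 509000 nM, and compound 3 gives 187000 nM, which places compound 3 second highest of the three numbers, with compound 1 nearest and compound 2 furthest. The two steps into compound 3 were modest but beyond the scatter: a 2.3-fold higher number from compound 1 to compound 3 (0.37 log units; beyond the scatter) and a 2.7-fold lower number from compound 2 to compound 3 (0.43 log units; beyond the scatter).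

Compound 4 `Cc1cccc(NC(=O)c2ccc(/N=N\c3c[nH]c4ccccc34)cc2)c1` is not yet measured. Relative to compound 3 the change is 3-methylphenyl in place of 4-chlorophenyl on an amide-type nitrogen. Within the data shown here, no measured pair swaps chlorine for methyl at the same place, so the bearing steps are only indirect: the move from 3-chlorophenyl to 4-chlorophenyl raised the number, and the move from 2-methylphenyl to 4-chlorophenyl lowered it. Taken together these suggest a step of modest size at most, in either direction, and most likely none beyond the scatter. The estimate for compound 4 in this assay is therefore 200000 nM, with a range from 80000 nM to 500000 nM, corresponding to an expected step of a 1.1-fold higher number from compound 3 to compound 4 (0.03 log units; within the scatter).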

Compound 4, half-maximal inhibitory concentration: 98900 nM
Estimate against measurement, compound 4: 2.0-fold (0.31 log units) above; the measured number falls inside the stated range.
By their numbers in this assay, from the lowest: compounds 1, 4 and 3 (each within the scatter of the next, the first and the last beyond it); then compound 2.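

Among these compounds, the first direct swap of chloro for methyl at one place gives a 1.2-fold higher number from compound 1 to compound 4 (0.09 log units; within the scatter) in this assay, so 3-methylphenyl and 3-chlorophenyl on the amide nitrogen are not separated. Moving the methyl matters more: 3-methylphenyl in place of 2-methylphenyl gives a 5.1-fold lower number from compound 2 to compound 4 (0.71 log units; beyond the scatter), a step beyond the scatter that shows the placement of the methyl on this aryl ring changes the number, as the placement of the chlorine did with a 2.3-fold higher number from compound 1 to compound 3 (0.37 log units; beyond the scatter). By contrast, 3-methylphenyl in place of 4-chlorophenyl, which changes both the substituent and its place, gives a 1.9-fold lower number from compound 3 to compound 4 (0.28 log units; within the scatter), which leaves those two compounds unseparated, and nothing shown gives a reason for any of these steps.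

Among the compounds shown here, whether methyl and chloro also match elsewhere on this aryl ring remains open, as the only direct pair is compound 1 and compound 4. Also open, from the compounds shown here alone, is how a methoxy group, an amine or a carboxylic acid on this ring would read in this assay.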